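A few compounds are considered here, and "the series" means these few. Any claim that something is new, unique, unknown or untested is made for them only; others in the source may bear on it.

Measured compounds in a functional assay (Homo sapiens) for inhibition of Nucleic Acid, tested at 100 uM; on this read-out higher numbers stand for more inhibition at the one concentration tested (going by the name of the read-out) and lower numbers for less inhibition:
compound 1 `OC[C@H]1OC(n2cnc3c(Nc4ccccc4)nccc32)[C@H](O)[C@@H]1O` — 4%
compound 2 `OC[C@H]1OC(n2cnc3c(SCc4ccccc4)nccc32)[C@H](O)[C@@H]1O` — 30%
compound 3 `[N-]=[N+]=Nc1nccc2c1ncn2C1O[C@H](CO)[C@@H](O)[C@H]1O` — 4%

Compound 3 sits level with compound 1 at the digits shown, the two together the lowest of the three values; the furthest is compound 2: a number 26 percentage points lower from compound 2 to compound 3 (beyond the scatter). Compound 4 `CNc1nccc2c1ncn2C1O[C@H](CO)[C@@H](O)[C@H]1O` differs from compound 3 in one place: methylamino in place of azido on an aromatic carbon. Among the compounds with values here, two measured steps bear on this. Exchanging anilino for azido gave no change at the digits printed from compound 1 to compound 3 (within the scatter), whereas exchanging benzylsulfanyl for azido gave a number 26 percentage points lower from compound 2 to compound 3 (beyond the scatter). Methylamino, like anilino, is an amine, and since the anilino-to-azido step was no change at the digits printed from compound 1 to compound 3 (within the scatter), no step beyond the scatter is expected here, a number 2 percentage points higher from compound 3 to compound 4 (within the scatter). Compound 4 is therefore estimated at 6%, with a range from -6% to 20%.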

Compound 4, a percentage reported as inhibition, at one concentration (the size of the read-out at that concentration, not a potency): 8%
Beside the measured number, compound 4's estimate is 2 percentage points below it, and the stated range covers the measured number.
By their numbers in this assay, from the lowest: compounds 1, 3 and 4 (each within the scatter of the next); then compound 2.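

In this assay, methylamino on this aromatic carbon gives a number 4 percentage points higher from compound 3 to compound 4 (within the scatter), and methyl in place of phenyl on the nitrogen gives a number 4 percentage points higher from compound 1 to compound 4 (within the scatter), so azido, anilino and methylamino all lie within the scatter of one another. Benzylsulfanyl remains apart from the new compound too, with a number 22 percentage points lower from compound 2 to compound 4 (beyond the scatter). Among these four compounds, only compound 2 stands beyond the scatter of the others.

On these data alone, whether the sulfur or the benzyl part carries that gap stays open, and a benzyloxy group or a methylsulfanyl group here would separate the two. Nothing at hand explains the gap.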